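Title: From compound 2 to compound 3 against monoamine oxidase A

The source may hold more compounds than are shown below. What is called first, only, known or untested is meant among the compounds shown, and "the series" means these compounds.

Measured compounds:
Compound 1, `Cc1cccc(COc2ccc(-c3nn(CCC#N)c(=O)o3)cc2)c1`, gives 20000 nM in an assay for inhibition of Amine oxidase [flavin-containing] A (Rattus norvegicus); a lower number here means a stronger inhibitor, a higher number a weaker inhibitor.
Compound 2, `COc1ccc(COc2ccc(-c3nn(CCC#N)c(=S)o3)cc2)cc1`, gives 4800 nM in this assay.

Compound 2 holds the lower of the two numbers in this assay; compound 1 lies beyond the scatter with its higher value. For the measured compounds named here, the two compounds differ in more than one place, so their values show only that compound 2 is the stronger inhibitor of the pair, without pointing to a single cause.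

Compound 3, `N#CCCn1nc(-c2ccc(OCc3cccc(Cl)c3)cc2)oc1=S`, has not yet been measured in this assay. It is reached from compound 2 by one change: 3-chlorophenyl in place of 4-methoxyphenyl on a saturated chain carbon bound to an oxygen on an aromatic ring. Going by the values given here, no measured pair in this set isolates such a change, so its effect is open.

The estimate for compound 3 in this assay is 4500 nM, with a range from 1200 nM to 16000 nM. This expectation means a step of a 1.1-fold lower number from compound 2 to compound 3 (0.03 log units; within the scatter) that is not expected to go beyond the scatter in either direction, since compound 2 with 4800 nM is the only anchor for it.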

Compound 3, half-maximal inhibitory concentration: 11000 nM
Compound 3: middle estimate off by 2.4-fold (0.39 log units), on the low side; the measured number falls inside the stated range.
By their numbers in this assay, from the lowest: compound 2; then compounds 3 and 1 (each within the scatter of the next).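

In this assay, for the compounds shown here, putting 3-chlorophenyl in place of 4-methoxyphenyl on a saturated chain carbon bound to an oxygen on an aromatic ring gives a 2.3-fold higher number from compound 2 to compound 3 (0.36 log units; beyond the scatter) as the first step in this set that isolates a single place. It shows that this position is not indifferent to the group it carries, although the step is modest and the 4-methoxyphenyl group of compound 2 gives the stronger inhibitor of this pair. The change alters both the substituent and where it stands on the phenyl ring, and no data shown explain the rise in the number or separate these two parts.

Still open, on these data alone, is how 4-chlorophenyl or 3-methoxyphenyl would read at this position, since either group would help separate the effect of the substituent from the effect of where it stands. Also open, as far as these compounds go, is whether the same exchange would give a comparable step on a core carrying the carbonyl of compound 1 rather than the thiocarbonyl of compound 2 and compound 3.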